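This account rests on a few compounds, and the source may have more. Where it says the series, first, only, none or still open, it means among the compounds named here.

Measured in a functional assay on HL-60 cells (Homo sapiens) for inhibition, read by CCK-8 assay, with a stated time of 48 h, tested at 20 uM; a lower number here means less inhibition of growth, a higher number more inhibition of growth at the concentration tested:

- Compound 1 `COc1ccc(S(=O)(=O)Oc2ccccc2/C=C(\C#N)C(=O)Nc2nnc(Cc3ccccc3)s2)cc1`: 100%
- Compound 2 `COc1ccc(S(=O)(=O)Oc2ccccc2/C=C(\C#N)C(=O)Nc2nnc(Cc3ccc(F)cc3)s2)cc1`: 100%
- Compound 3 `COc1ccc(S(=O)(=O)Oc2ccccc2/C=C(\C#N)C(=O)Nc2nnc(Cc3cccc(F)c3)s2)cc1`: 100%

Among the compounds with values here, compound 3 stands level with compound 1 and compound 2 in this assay, and no measured compound separates from the others. The next compound, compound 4 `COc1ccc(S(=O)(=O)Oc2ccccc2/C=C(\C#N)C(=O)Nc2nnc(Cc3ccc(C)cc3)s2)cc1`, differs from compound 3 in one place: 4-methylphenyl in place of 3-fluorophenyl on a saturated chain carbon bound to an aromatic carbon. In words, this is 4-methylphenyl in place of 3-fluorophenyl on a saturated chain carbon bound to an aromatic carbon.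

Within the data shown here, three measured steps bear on this change. Fluoro in place of hydrogen on an aromatic carbon gave no change at the digits printed from compound 1 to compound 2 (within the scatter) and no change at the digits printed from compound 1 to compound 3 (within the scatter). 3-fluorophenyl in place of 4-fluorophenyl gave no change at the digits printed from compound 2 to compound 3 (within the scatter). None of these steps involves 4-methylphenyl, so they offer only indirect guidance, though all three leave the read-out unmoved. On that evidence, the estimated step of a number 2 percentage points lower from compound 3 to compound 4 (within the scatter) is expected to stay within the scatter, with no firm direction. Compound 4 is expected at 98%, with an estimated range of 85% to 100%.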

Compound 4, percent growth inhibition at one concentration: 100%
Beside the measured number, compound 4's estimate is 2 percentage points below it; low and high end bracket the measured number.
By their numbers in this assay, from the lowest: compounds 1, 2, 3 and 4 (each within the scatter of the next).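

In this assay the change from fluoro to a carbon substituent on the benzyl group leaves the read-out where it was: 4-methylphenyl in place of 3-fluorophenyl gave no change at the digits printed from compound 3 to compound 4 (within the scatter) and methyl in place of fluoro gave no change at the digits printed from compound 2 to compound 4 (within the scatter) while methyl in place of hydrogen gave no change at the digits printed from compound 1 to compound 4 (within the scatter) in the same read-out. The four compounds now share one value at the single concentration tested, and no order among hydrogen, fluoro and methyl at this place can be drawn from it. No evidence is available that accounts for this result.

Going by these compounds, whether an amine or a carboxylic acid on this benzyl group, or a longer chain in place of its saturated chain carbon, would hold the read-out at this level remains open. On these data alone, how the four compounds would rank at lower concentrations also remains open.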